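The source may hold more compounds than are shown below. What is called first, only, known or untested is meant among the compounds shown, and "the series" means these compounds.

Compound 1 `CCCCOc1ccc(C(=O)/C=C/c2c(/C=C/c3ccc(OC)cc3)cc(OC)cc2OC)cc1`: 8.7 ug/mL
Compound 2 `CCOc1ccc(C(=O)/C=C/c2c(/C=C/c3ccc(OC)cc3)cc(OC)cc2OC)cc1`: 7.5 ug/mL

In a functional assay on A549 cells (Homo sapiens) for antiproliferative activity, read by MTT assay, with a stated time of 48 h (a higher number here means a weaker inhibitor, a lower number a stronger inhibitor), compound 2 gives the lowest of the two numbers, with compound 1 nearest; the step of a 1.2-fold lower number from compound 1 to compound 2 (0.06 log units; within the scatter) separates them and lies within the scatter. Compound 3 `COc1ccc(/C=C/c2cc(OC)cc(OC)c2/C=C/C(=O)c2ccccc2)cc1` differs from compound 2 by hydrogen in place of ethoxy on an aromatic carbon. For the measured compounds named here, the only measured step that bears on this change is the one from compound 1 to compound 2, where the chain on the aromatic oxygen was also shortened, and it stayed within the scatter. Compound 3 is therefore expected to show a step of a 1.1-fold higher number from compound 2 to compound 3 (0.03 log units; within the scatter), no larger than the scatter. Compound 3 is estimated at 8 ug/mL, between 4 ug/mL and 16 ug/mL.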

Compound 3, half-maximal inhibitory concentration: 3.9 ug/mL
Compound 3: the middle estimate sits 2.1-fold (0.31 log units) above what was measured; the whole stated range lies above it.
By their numbers in this assay, from the lowest: compounds 3, 2 and 1 (each within the scatter of the next, the first and the last beyond it).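

In this assay, an unsubstituted aromatic carbon, para to a large group, holds up as well as one bearing ethoxy: replacing that whole group with hydrogen gives a 1.9-fold lower number from compound 2 to compound 3 (0.28 log units; within the scatter), so no oxygen substituent is needed at this position. Replacing butoxy with hydrogen gives a 2.2-fold lower number from compound 1 to compound 3 (0.35 log units; beyond the scatter), a modest step and the only one here that clears the scatter. Nothing measured here accounts for this result.

The compounds shown leave open how an amine or a carboxylic acid would fare on this aromatic carbon. They also leave open whether a chain longer than butoxy would move the number further.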